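Capping a Phenol: the Ethoxy Analogue of Compound 2

The compounds below may be only part of what the source reports. "The series", "measured", "known", "first", "only" and "open" are said of these compounds alone.

Going by the values given here, compound 2 `Oc1ccc(/C=N\NC(=S)NC2CCCCC2)cc1` gives the highest number of the two measured so far in a functional assay on MDA-MB-468 cells (Homo sapiens) for inhibition, read by WST assay, with a stated time of 48 h (a lower number here means a stronger inhibitor, a higher number a weaker inhibitor), namely 242000 nM; compound 1 `S=C(N/N=C\c1ccc(Cl)cc1)NC1CCCCC1` gives 41600 nM. Among the compounds with values here, the only measured step, a 5.8-fold higher number from compound 1 to compound 2 (0.76 log units; beyond the scatter), shows that the group on that aromatic carbon clearly moves the number. Compound 3 `CCOc1ccc(/C=N\NC(=S)NC2CCCCC2)cc1` differs from compound 2 by ethyl in place of hydrogen on an oxygen on an aromatic ring. Within the data shown here, no measured step mirrors this change directly, so the expectation leans on compound 1 with its 41600 nM alone. Compound 3 is therefore expected to give a modestly lower number, a 2.7-fold lower number from compound 2 to compound 3 (0.43 log units; beyond the scatter), estimated at 90000 nM with a range from 30000 nM to 270000 nM.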

Compound 3, half-maximal inhibitory concentration: 252000 nM
Estimate against measurement, compound 3: 2.8-fold (0.45 log units) below, and the stated range covers the measured number.
By their numbers in this assay, from the lowest: compound 1; then compounds 2 and 3 (each within the scatter of the next).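

In this assay capping the oxygen with ethyl gives a 1.0-fold higher number from compound 2 to compound 3 (0.02 log units; within the scatter) and so leaves the number unmoved: on this oxygen, hydrogen and ethyl cannot be told apart. Ethoxy also stays clear of chloro, with a 6.1-fold higher number from compound 1 to compound 3 (0.78 log units; beyond the scatter) as the step, so hydroxy and ethoxy both give higher numbers than chloro on that aromatic carbon. Nothing measured here explains this result. On these data alone, whether methoxy or a longer chain on the oxygen would read the same remains open, as does whether an amine on that aromatic carbon would come closer to compound 1.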